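Nitro for Chloro on a Shared Thiazolylidene-Hydrazide Core

A few compounds are considered here, and "the series" means these few. Any claim that something is new, unique, unknown or untested is made for them only; others in the source may bear on it.

Measured so far:
- Compound 1 `O=C(CSc1nnnn1-c1ccccc1)N/N=c1/scc(-c2ccc(Br)cc2)n1-c1ccccc1`: 433 ug/mL
- Compound 2 `O=C(CSc1nnnn1-c1ccccc1)N/N=c1/scc(-c2ccc(Cl)cc2)n1-c1ccccc1`: 313 ug/mL

Of the compounds shown here, two have been measured in an ADME assay on NIH3T3 cells (Mus musculus) for cytotoxicity, read by MTT assay, with a stated time of 24 h; on this read-out higher numbers stand for weaker inhibition and lower numbers for stronger inhibition. Compound 1 gives 433 ug/mL and compound 2 gives 313 ug/mL. Among the compounds with values here, the only step between them, a 1.4-fold lower number from compound 1 to compound 2 (0.14 log units; within the scatter), leaves the two numbers within the scatter of one another, so neither can be ranked above the other. Within the data shown here, compound 2 has the lowest of the two numbers, with compound 1 as its only neighbour.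

Compound 3 `O=C(CSc1nnnn1-c1ccccc1)N/N=c1/scc(-c2ccc([N+](=O)[O-])cc2)n1-c1ccccc1` has not yet been measured in this assay. It differs from compound 2 by nitro in place of chloro on an aromatic carbon. Among the measured compounds shown here, no measured step involves a nitro group, so the one step at hand, a 1.4-fold lower number from compound 1 to compound 2 (0.14 log units; within the scatter), bears only loosely on it: it shows that swapping the group on this aromatic carbon has so far left the number within the scatter. Compound 3 is therefore expected to sit close to compound 2, with the step of a 1.0-fold lower number from compound 2 to compound 3 (0.02 log units; within the scatter) expected to stay within the scatter. The estimate for compound 3 is 300 ug/mL, with a range from 150 ug/mL to 600 ug/mL.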

Compound 3, half-maximal inhibitory concentration: 14.3 ug/mL
Compound 3: the middle estimate sits 21-fold (1.32 log units) above what was measured; the whole stated range lies above it.
By their numbers in this assay, from the lowest: compound 3; then compounds 2 and 1 (each within the scatter of the next).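

The place on the aromatic ring para to a large group turns out not to be indifferent in this assay, since the change from 4-chlorophenyl to 4-nitrophenyl gives a 22-fold lower number from compound 2 to compound 3 (1.34 log units; beyond the scatter) and the change from bromo to nitro gives a 30-fold lower number from compound 1 to compound 3 (1.48 log units; beyond the scatter) as well. Within the data shown here, the earlier exchange of one halogen for the other had stayed within the scatter, so it gave no sign that this place could move the number so far. Compound 3 now stands clearly apart from compound 1 and compound 2 as the stronger inhibitor of the three, and no measured evidence here accounts for that gap.

As far as these compounds go, what remains open is whether this shift belongs to the nitro group alone or would also appear with a nitrile, an amine or a carboxylic acid at the same place. The compounds shown also leave open whether the same exchange would have a similar effect on any core other than the shared one.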